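The source may report more compounds than this note shows. Statements on the series, on what has been measured and on what is new or still open speak of the compounds shown alone.

Compound 1, `CCOC(=O)C12C(=O)OCC=C1COC2c1ccc(F)cc1`: in a functional assay on A549 cells (Homo sapiens) for cytotoxicity, read by MTT assay (a higher number here means a weaker inhibitor, a lower number a stronger inhibitor), compound 1 gives > 1000000 nM, which is a limit of the assay and not a number.
Compound 2, `CCOC(=O)C12C(=O)OCC=C1COC2c1ccc(Cl)cc1`: in this assay compound 2 gives > 1000000 nM, again a limit.
Compound 3, `CCOC(=O)C12C(=O)OCC=C1COC2c1ccc(Br)cc1`: in this assay compound 3 gives > 1000000 nM, once more a limit.

Compound 3 therefore stands nowhere in particular among the numbers shown: its own value is a limit, and the two further values are limits as well. All three readings sit at the limit of > 1000000 nM in this assay, at which 3 of the 3 values shown sit. The three steps between the measured compounds, a step that the two limits leave unreadable from compound 1 to compound 2, a step that the two limits leave unreadable from compound 1 to compound 3 and a step that the two limits leave unreadable from compound 2 to compound 3, each exchange one halogen for another on the aromatic ring, and none of them can be read in size because every value involved sits at the limit of > 1000000 nM in this assay, at which 3 of the 3 values shown sit.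

Compound 4, `CCOC(=O)C12C(=O)OCC=C1COC2c1cccs1`, differs from compound 3 by thiophen-2-yl in place of 4-bromophenyl on a saturated ring carbon. Going by the values given here, no measured step touches this kind of change, and the halogen exchanges that were measured gave nothing readable, so the expectation rests on the three limits alone. Compound 4 is expected to give 1000000 nM in this assay, with a range from 200000 nM to 5000000 nM. That estimate means a number no higher from compound 3 to compound 4 (the limit leaves the size open), which is expected to be no step beyond the scatter, and a further limit report is the likeliest outcome.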

Compound 4, half-maximal inhibitory concentration: > 1000000 nM
Compound 4: no number, only a limit; the forecaster's own chance of this, stated with the estimate: 80%; the middle value sits exactly at the limit.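

In this assay compound 4 gives > 1000000 nM, again a limit. The steps joining compound 4 to compound 1, compound 2 and compound 3 cannot be read in size, because all the values sit at one limit: the limit of > 1000000 nM in this assay, at which 4 of the 4 values shown sit.

The compounds shown leave open whether thiophen-2-yl, 4-fluorophenyl, 4-chlorophenyl and 4-bromophenyl differ at all in this assay, and what change to the shared core would yield a readable number.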